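The source may hold more compounds than are shown below. What is called first, only, known or untested is meant among the compounds shown, and "the series" means these compounds.

Of the compounds shown here, three have been tested in a functional assay on the whole organism (strain albino) for inhibition, with Rattus norvegicus as the target, read by paw edema, with a stated time of 4 h, at a dose of 0.28 mmol/kg by the oral route; on this read-out higher numbers stand for more inhibition at the one dose given (going by the name of the read-out) and lower numbers for less inhibition. Compound 3 `CCn1c(SC/C(=N/O)c2ccccc2)nnc1-c1ccc(OC)c(OC)c1` gives 82%. Compound 1 `CCn1c(SC/C(=N/O)c2ccccc2)nnc1-c1cc(OC)c(OC)c(OC)c1` carries an additional methoxy group, the change being (methoxy in place of hydrogen on an aromatic carbon), and gives 79%; this change made a step of a number 3 percentage points lower from compound 3 to compound 1 (within the scatter). Compound 2 `O=C(CSc1nnc(-c2ccccc2)n1-c1ccccc1)c1ccccc1` has a different core, and how its core differs from that of compound 3 is not broken down here. In this assay compound 2 gives 68%. Compound 4 `COc1ccc(-c2nnc(SCC(=O)c3ccccc3)n2-c2ccccc2)cc1` has not yet been measured. It differs from compound 2 by methoxy in place of hydrogen on an aromatic carbon. Among the compounds with values here, this is the same kind of change as the one from compound 3 to compound 1, though the place differs: in compound 4 the methoxy sits para to a large group, whereas in compound 1 it sits ortho to a methoxy group, meta to a large group and meta to a methoxy group. For compound 4 a step of about a number 2 percentage points higher from compound 2 to compound 4 (within the scatter) is expected, because a number 3 percentage points lower from compound 3 to compound 1 (within the scatter) lay within the scatter. Compound 4 is thus estimated at 70%, with a range from 58% to 82%.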

Compound 4, a percentage reported as inhibition, in the whole organism at one dose (the size of the read-out at that dose, not a potency): 68%
Compound 4: the middle estimate sits 2 percentage points above what was measured; the range from low to high includes it.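

In this assay, the change from phenyl to 4-methoxyphenyl gives no change at the digits printed from compound 2 to compound 4 (within the scatter). Set beside the same change on the other core, the two steps do not differ: the same change on two cores in this assay, a number 3 percentage points lower (within the scatter) from compound 3 to compound 1 and no change at the digits printed (within the scatter) from compound 2 to compound 4, 3 percentage points apart, within the scatter of two such steps. So on these two cores, at this one dose, adding a methoxy group leaves the read-out within the scatter, but this does not show that the same would hold on other cores, and the methoxy also sits in a different place on each core.

As far as these compounds go, it remains open whether an amine or a carboxylic acid in place of the methoxy group on compound 4 would give a step beyond the scatter. The same question stands for a longer chain such as butoxy.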